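Chloro for nitro: cytotoxicity notes on a two-compound series

This account rests on a few compounds, and the source may have more. Where it says the series, first, only, none or still open, it means among the compounds named here.

Measured so far:
compound 1, `O=C(Cn1c(=O)oc2cc(Cl)ccc21)NCc1cccs1`: 20.3%
compound 2, `O=C(Cn1c(=O)oc2cc([N+](=O)[O-])ccc21)NCc1ccccn1`: 21.8%

In an ADME assay on RAW264.7 cells (Mus musculus) for cytotoxicity, read by MTT assay, with a stated time of 72 h, tested at 50 uM (on this read-out lower numbers stand for a weaker effect and higher numbers for a stronger effect at the one concentration tested), compound 2 gives 21.8%, the highest of the two numbers shown. Its nearest neighbour, compound 1, gives 20.3% in this assay, a gap that sits within the scatter, so no order between the two can be read. For the measured compounds named here, no pair of measured compounds differs in one place, so no measured step is available.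

Compound 3, `O=C(Cn1c(=O)oc2cc(Cl)ccc21)NCc1ccccn1`, differs from compound 2 by chloro in place of nitro on an aromatic carbon. Going by the values given here, with no measured step to lean on, the expected step of a number 0.8 percentage points lower from compound 2 to compound 3 (within the scatter) in this assay is none beyond the scatter. Compound 3 is expected to give about 21% in this assay, in the range 10% to 33%, because compound 1 with the same chloro group gives 20.3%.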

Compound 3, a percentage reported as inhibition, at one concentration (the size of the read-out at that concentration, not a potency): 36.2%
Estimate against measurement, compound 3: 15.2 percentage points below, and the stated range ends below it.
By their numbers in this assay, from the lowest: compounds 1 and 2 (each within the scatter of the next); then compound 3.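

In this assay, chloro in place of nitro on the aromatic carbon gives a number 14.4 percentage points higher from compound 2 to compound 3 (beyond the scatter) with pyridin-2-yl held fixed, so this place on the shared core does bear on the read-out. Chloro alone does not set the number: pyridin-2-yl in place of thiophen-2-yl on the saturated chain carbon gives a number 15.9 percentage points higher from compound 1 to compound 3 (beyond the scatter) with chloro held fixed, and the near-equal values of compound 1 and compound 2 could not show either step. Nothing shown here accounts for these steps.

Whether the chloro-for-nitro step carries over when thiophen-2-yl replaces pyridin-2-yl remains open, since the compounds shown do not complete that pair. From the compounds shown here alone, how an amine or a methoxy group on the same aromatic carbon would read, and how the read-out would behave at other concentrations, also remain open.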